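This account rests on a few compounds, and the source may have more. Where it says the series, first, only, none or still open, it means among the compounds named here.

Compound 3 `CC(=O)NS(=O)(=O)c1ccc(N/C(S)=N\c2ccnc3cc(C(F)(F)F)ccc23)cc1` carries an acetyl group on its sulfonamide nitrogen. In a functional assay on AS49-RAW cells (Homo sapiens) for antiproliferative activity, read by sulforhodamine B assay, with a stated time of 48 h (a higher number here means a weaker inhibitor, a lower number a stronger inhibitor), compound 3 gives 37600 nM, the top number among the three in hand, though its gap to each of the others stays within the scatter: compound 1 `Nc1ccc(S(=O)(=O)Nc2ccnc3cc(C(F)(F)F)ccc23)cc1` gives 29200 nM, and compound 2 `O=C(Nc1ccccc1)Nc1ccc(S(=O)(=O)Nc2ccnc3cc(C(F)(F)F)ccc23)cc1` gives 24500 nM. The only step that connects two of these compounds, a 1.2-fold lower number from compound 1 to compound 2 (0.08 log units; within the scatter), concerned the nitrogen on the aromatic ring rather than the sulfonamide nitrogen, and it left the number within the scatter. Compound 4 `Cc1cc(NS(=O)(=O)c2ccc(N/C(S)=N\c3ccnc4cc(C(F)(F)F)ccc34)cc2)on1` differs from compound 3 by 3-methyl-1,2-oxazol-5-yl in place of acetyl on a sulfonamide nitrogen. For the measured compounds named here, no measured step touches the sulfonamide nitrogen, so nothing in these three numbers points in one direction or the other, and the one comparison available was flat. The expected step is therefore a 1.3-fold lower number from compound 3 to compound 4 (0.10 log units; within the scatter), meaning no movement beyond the scatter. Compound 4 is estimated at 30000 nM in this assay, with a range from 10000 nM to 90000 nM.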

Compound 4, half-maximal inhibitory concentration: 60200 nM
Beside the measured number, compound 4's estimate is 2.0-fold (0.30 log units) below it, within the range that was stated.
By their numbers in this assay, from the lowest: compounds 2, 1, 3 and 4 (each within the scatter of the next, the first and the last beyond it).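

For the compounds shown here, this is the first measured step at the sulfonamide nitrogen, and in this assay the step of a 1.6-fold higher number from compound 3 to compound 4 (0.20 log units; within the scatter) stays within the scatter, even though 3-methyl-1,2-oxazol-5-yl is a larger group than acetyl and brings a five-membered aromatic ring. For this one pair, then, the two groups on that nitrogen cannot be told apart in this assay. The readings with a ring there and with a small carbonyl-bearing chain there lie within the scatter of each other. Nothing is available that would explain the reading of either compound. The compounds shown leave open whether a methyl group, a phenyl ring or a carboxylic acid chain on the sulfonamide nitrogen would move the number beyond the scatter. They also leave open how a plain hydrogen there would compare with compound 3 and compound 4.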